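A few compounds are considered here, and "the series" means these few. Any claim that something is new, unique, unknown or untested is made for them only; others in the source may bear on it.

Compound 1 `CCOCCN(C[C@@H](O)CN1CCCC2(CCN(c3ncnc4ccccc34)C2)C1)S(=O)(=O)c1c(C)cccc1C`: 2400 nM
Compound 2 `Cc1cccc(C)c1S(=O)(=O)N1CCC[C@H]1[C@@H](O)CN1CCC[C@@]2(CCN(c3ncnc(N)c3C3CC3)C2)C1`: 690 nM
Compound 3 `Cc1cccc(C)c1S(=O)(=O)NC[C@@H](O)CN1CCC[C@@]2(CCN(c3ncnc(N)c3C3CC3)C2)C1`: 900 nM

In an assay on LNCaP cells for inhibition of RAC-alpha serine/threonine-protein kinase (Homo sapiens) (on this read-out higher numbers stand for weaker inhibition and lower numbers for stronger inhibition), compound 3 gives 900 nM, the second highest of the three numbers. Its nearest neighbour is compound 2, whose value lies within the usual scatter of it, so no order between these two can be claimed. Compound 1 sits beyond the scatter above compound 3, the widest gap in this small set.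

Compound 4 `Cc1noc(C)c1S(=O)(=O)NC[C@@H](O)CN1CCC[C@@]2(CCN(c3ncnc(N)c3C3CC3)C2)C1` is not yet measured. It differs from compound 3 in one place: 3,5-dimethyl-1,2-oxazol-4-yl in place of 2,6-dimethylphenyl on a sulfonyl sulfur. Going by the values given here, no measured pair shows this exchange, so the step has no precedent here. Compound 4 is expected to stay close to compound 3, with a step of a 1.3-fold higher number from compound 3 to compound 4 (0.12 log units; within the scatter) that need not leave the scatter. The estimate for compound 4 is 1200 nM, ranging from 400 nM to 3500 nM.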

Compound 4, half-maximal inhibitory concentration: 490 nM
Compound 4: the middle estimate sits 2.4-fold (0.39 log units) above what was measured; low and high end bracket the measured number.
By their numbers in this assay, from the lowest: compounds 4, 2 and 3 (each within the scatter of the next); then compound 1.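

Going from 2,6-dimethylphenyl to 3,5-dimethyl-1,2-oxazol-4-yl on a sulfonyl sulfur gives, in this assay, a 1.8-fold lower number from compound 3 to compound 4 (0.26 log units; within the scatter) and so shows that this position takes a five-membered aromatic ring with 2 hetero atoms in place of a six-membered aromatic ring of carbon only, with no step beyond the scatter. The 2 hydrogen-bond acceptors that enter leave the reading within that scatter. Nothing available here accounts for this result.

Open, from the compounds shown here alone, is how a pyridine ring, a plain methyl or an unsubstituted phenyl would read on the same sulfur. Also open, going by these compounds, is whether the same exchange would read alike on the core of compound 2.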